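The compounds below may be only part of what the source reports. "The series", "measured", "known", "first", "only" and "open" are said of these compounds alone.

Measured so far:
compound 1, `Oc1nc2nonc2nc1Nc1ccc(SC(F)(F)F)cc1`, 1400 nM;
compound 2, `CCCCCCc1ccc(Nc2nc3nonc3nc2O)cc1`, 4700 nM.

Among the measured compounds shown here, compound 2 stands at the higher of the two numbers known in an assay on mitochondria from L6 cells (Rattus norvegicus) for activation, with a stated time of 90 min (on this read-out higher numbers stand for an effect only at larger amounts of compound and lower numbers for an effect already at smaller amounts), its nearest neighbour being compound 1 with its 1400 nM. For the measured compounds named here, the only step measured, a 3.4-fold higher number from compound 1 to compound 2 (0.53 log units; beyond the scatter), is of modest size and beyond the scatter.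

Compound 3, `Oc1nc2nonc2nc1Nc1ccc(Cl)cc1`, has not been measured. It differs from compound 2 as follows: chloro in place of hexyl on an aromatic carbon. Going by the values given here, no measured step shows exactly this change; the single step that bears on it is the one from compound 1 to compound 2, in which hexyl entered at this place and the number rose, a 3.4-fold higher number from compound 1 to compound 2 (0.53 log units; beyond the scatter). Removing hexyl again is therefore expected to move the number back toward that of compound 1, a step in the lowering direction of roughly the size seen, a 3.1-fold lower number from compound 2 to compound 3 (0.50 log units; beyond the scatter). For compound 3 the estimate in this assay is 1500 nM, with a range from 500 nM to 5000 nM.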

Compound 3, half-maximal effective concentration: 11700 nM
The estimate for compound 3 lay 7.8-fold (0.89 log units) below the measured number; the whole stated range lies below it.
By their numbers in this assay, from the lowest: compound 1; then compound 2; then compound 3.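

In this assay, chloro on this aromatic carbon does not bring the number back toward that of compound 1: the change from hexyl to chloro runs the other way, a 2.5-fold higher number from compound 2 to compound 3 (0.40 log units; beyond the scatter), so hexyl is not the group giving the highest number at this place. Chloro in place of (trifluoromethyl)sulfanyl gives the larger rise, an 8.4-fold higher number from compound 1 to compound 3 (0.92 log units; beyond the scatter), and compound 3 carries the highest number of the three, with its steps to both others beyond the scatter. At this one place the single chlorine thus sits at the high end, and the hexyl chain of 6 carbons lies in the middle.

No measurement at hand accounts for this order. As far as these compounds go, whether a shorter chain such as butyl, a methoxy group, an amine or a carboxylic acid on this carbon would fall below compound 1 or above compound 3 remains open.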